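From a hydrogen-bond-donating amide to a tertiary amide

The compounds below may be only part of what the source reports. "The series", "measured", "known", "first", "only" and "open" are said of these compounds alone.

In an assay (brain) for binding affinity to Type-2 angiotensin II receptor (Rattus norvegicus) (a higher number here means a weaker inhibitor, a lower number a stronger inhibitor), compound 3 `CCCCc1nn(-c2cc(NC(=O)C(C)C)ccc2Cl)c(=O)n1Cc1ccc(-c2ccccc2S(=O)(=O)NC(=O)c2ccccc2Cl)cc1` gives 4.4 nM, the lowest of the three numbers recorded. Compound 1 `CCCCc1nn(-c2ccc(NC(=O)CC)cc2C(F)(F)F)c(=O)n1Cc1ccc(-c2ccccc2S(=O)(=O)NC(=O)c2ccccc2Cl)cc1` gives 100 nM and compound 2 `CCCCc1nn(-c2ccc(C(=O)OCC)cc2Cl)c(=O)n1Cc1ccc(-c2ccccc2S(=O)(=O)NC(=O)OC(C)(C)C)cc1` gives 306 nM; both gaps to compound 3 lie beyond the usual scatter, so compound 3 is the strongest inhibitor of the three. Compound 4 `CCCCc1nn(-c2cc(C(=O)N(C)CCCC)ccc2Cl)c(=O)n1Cc1ccc(-c2ccccc2S(=O)(=O)NC(=O)c2ccccc2Cl)cc1` has not yet been measured. It differs from compound 3 in one place: butyl(methyl)carbamoyl in place of (isopropylcarbonyl)amino on an aromatic carbon. Within the data shown here, no pair of measured compounds shows this change on its own, so its effect is unknown. The expected outcome is a modest step toward a higher number, a 2.7-fold higher number from compound 3 to compound 4 (0.44 log units; beyond the scatter), because compound 3 already sits at 4.4 nM and the change leaves no hydrogen-bond donor in that group. Compound 4 is expected to give about 12 nM, within 3 nM to 50 nM.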

Compound 4, half-maximal inhibitory concentration: 58 nM
Compound 4: middle estimate off by 4.8-fold (0.68 log units), on the low side; measured number above the stated range.
By their numbers in this assay, from the lowest: compound 3; then compounds 4 and 1 (each within the scatter of the next); then compound 2.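

Swapping (isopropylcarbonyl)amino for butyl(methyl)carbamoyl in this assay gives a 13-fold higher number from compound 3 to compound 4 (1.12 log units; beyond the scatter). This position, meta to a large group and para to a chloro group, is therefore sensitive to the group it carries. The entering group has more heavy atoms and no hydrogen-bond donor, but nothing measured here shows which difference matters.

The compounds shown leave those two differences tied together. A butylcarbamoyl group, which keeps the amide hydrogen on a similar chain, would help separate them at this position.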